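Removing a Fluorine from an Aryl Selenocyanate Carbamate

A few compounds are considered here, and "the series" means these few. Any claim that something is new, unique, unknown or untested is made for them only; others in the source may bear on it.

Measured compounds in a functional assay on HT-29 cells (Homo sapiens) for cytotoxicity, read by MTT assay, with a stated time of 72 h; a lower number here means that less compound is tolerated, a higher number that more compound is tolerated:
compound 1 `C=CCOC(=O)Nc1ccc([Se]C#N)cc1` gives 72800 nM
compound 2 `CCCCCCOC(=O)Nc1ccc([Se]C#N)cc1` gives 69900 nM
compound 3 `N#C[Se]c1ccc(NC(=O)Oc2ccc(F)cc2)cc1` gives 66500 nM

Compound 3 has the lowest of the three numbers, but its gaps to compound 2 and to compound 1 both lie within the scatter, so the three stand as equals. Compound 4 `N#C[Se]c1ccc(NC(=O)Oc2ccccc2)cc1` differs from compound 3 by a single change: hydrogen in place of fluoro on an aromatic carbon. The only step measured between two of these compounds is a 1.0-fold lower number from compound 1 to compound 2 (0.02 log units; within the scatter), which swaps one chain for another on the saturated chain carbon bound to an oxygen next to a carbonyl group and leaves the number where it was. Going by the values given here, no measured step touches the fluoro group, so nothing here speaks for a shift beyond the scatter in this assay. Compound 4 is therefore expected to give 70000 nM, within a range from 35000 nM to 140000 nM, an estimated step of a 1.1-fold higher number from compound 3 to compound 4 (0.02 log units; within the scatter).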

Compound 4, concentration lethal to 50% of the cells: 71700 nM
Compound 4: middle estimate off by 1.0-fold (0.01 log units), on the low side; the range from low to high includes it.
By their numbers in this assay, from the lowest: compounds 3, 2, 4 and 1 (each within the scatter of the next).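

In this assay, hydrogen in place of fluoro on an aromatic carbon, para to a large group, gives a 1.1-fold higher number from compound 3 to compound 4 (0.03 log units; within the scatter) and so this position shows no response to losing the fluorine. Phenyl in place of hexyl gives a 1.0-fold higher number from compound 2 to compound 4 (0.01 log units; within the scatter) and phenyl in place of allyl gives a 1.0-fold lower number from compound 1 to compound 4 (0.01 log units; within the scatter) so these three groups read alike here. Nothing measured explains this lack of change. As far as these compounds go, whether a chlorine, a methoxy group or an amine at this position would move the number stays open.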